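Series notes: aryl swap on the five-membered core, potassium channel inhibition

The source may report more compounds than this note shows. Statements on the series, on what has been measured and on what is new or still open speak of the compounds shown alone.

Measured compounds:
compound 1 `Cc1cccc(-c2nnc([C@H](C)NC(=O)c3cc(C4CC4)nn3C)o2)c1` — > 30000 nM
compound 2 `Cc1cccc(-c2nc(C(C)NC(=O)c3cc(C(F)(F)F)nn3C)no2)c1` — 977 nM
compound 3 `Cc1cncc(-c2noc([C@H](C)NC(=O)c3cc(C(F)(F)F)nn3C)n2)c1` — 1370 nM

In an assay on T-REx-293 cells for inhibition of potassium channel subfamily T member 1 (Homo sapiens), read by patch clamp (a higher number here means a weaker inhibitor, a lower number a stronger inhibitor), compound 1 returns only a limit, > 30000 nM; the value is a limit of the assay and not a number, as the limit of > 30000 nM in this assay, at which 1 of the 3 values shown sits, records. Compound 2 gives 977 nM in this assay. Compound 3 gives 1370 nM in this assay, the highest of the two numbers shown; the gap to compound 2 lies within the usual scatter, so the two read as equivalent.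

Compound 4 `C[C@H](NC(=O)c1cc(C(F)(F)F)nn1C)c1nc(-c2ccnc(C(F)F)c2)no1` is not yet measured in this assay. It differs from compound 3 by a group of 9 heavy atoms (6 carbon, 1 nitrogen, 2 fluorine; one six-membered aromatic ring with 1 hetero atom) in place of a group of 7 heavy atoms (6 carbon, 1 nitrogen; one six-membered aromatic ring with 1 hetero atom), on an aromatic carbon, the change sitting on an aromatic carbon of the five-membered ring with two nitrogen and one oxygen, two ring bonds from the ring oxygen. Within the data shown here, no measured pair shows this change, so no step size can be read from the data. The expectation for the step from compound 3 to compound 4 is none beyond the scatter, or at most a modest one, a 1.4-fold lower number from compound 3 to compound 4 (0.14 log units; within the scatter). Compound 4 is therefore estimated at 1000 nM in this assay, within a range of 300 nM to 4000 nM.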

Compound 4, half-maximal inhibitory concentration: 61 nM
Compound 4: middle estimate off by 16-fold (1.21 log units), on the high side; the whole stated range lies above it.
By their numbers in this assay, from the lowest: compound 4; then compounds 2 and 3 (each within the scatter of the next). At a limit, above all of these: compound 1.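

In this assay the aromatic carbon between two ring nitrogen atoms proves to be a sensitive position: replacing 5-methylpyridin-3-yl with the group of 9 heavy atoms carrying 2 fluorine gives a 22-fold lower number from compound 3 to compound 4 (1.35 log units; beyond the scatter) in this single pair. Among these compounds, the earlier compounds offered no matched pair at this position, so this is the first readable step there, and it shows that a change confined to this six-membered aromatic ring can alter the number substantially on an unchanged remainder of the molecule. No measurement shown bears on the origin of this step.

Still open, on these data alone, is whether the step belongs to the fluorine atoms or to their placement on the six-membered aromatic ring, as this one change alters both. Also open, as far as these compounds go, is how a nitrile or an amine on that ring would read in this assay.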